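Triazole-free account: aryl swaps at a shared limit

The source may hold more compounds than are shown below. What is called first, only, known or untested is meant among the compounds shown, and "the series" means these compounds.

Compound 3 `Cc1ccc(-n2nncc2CN2C(=O)C3(C(C#N)=C(N)Oc4c(N)cc5nc6ccccc6nc5c43)c3ccccc32)cc1C` carries a 3,4-dimethylphenyl group on the aromatic nitrogen of a five-membered aromatic ring with 3 nitrogen. In an ADME assay on HUVEC cells (Homo sapiens) for antiproliferative activity, read by MTT assay, with a stated time of 48 h (a higher number here means a weaker inhibitor, a lower number a stronger inhibitor), compound 3 gives only a limit of the assay, > 50000 nM. Compound 1 `Cc1ccccc1-n1nncc1CN1C(=O)C2(C(C#N)=C(N)Oc3c(N)cc4nc5ccccc5nc4c32)c2ccccc21`, bearing a 2-methylphenyl group at that position, likewise reaches only a limit in this assay, > 50000 nM. Compound 2 `CCc1ccccc1-n1nncc1CN1C(=O)C2(C(C#N)=C(N)Oc3c(N)cc4nc5ccccc5nc4c32)c2ccccc21`, bearing a 2-ethylphenyl group, also gives only a limit in this assay, > 50000 nM. Compound 3 thus stands level with the other two, all three sitting at the limit of > 50000 nM in this assay, at which 3 of the 3 values shown sit. The steps a step that the two limits leave unreadable from compound 1 to compound 3, a step that the two limits leave unreadable from compound 2 to compound 3 and a step that the two limits leave unreadable from compound 1 to compound 2 have no readable size. Compound 4 `CCc1cccc(C)c1-n1nncc1CN1C(=O)C2(C(C#N)=C(N)Oc3c(N)cc4nc5ccccc5nc4c32)c2ccccc21` differs from compound 3 as follows: 2-ethyl-6-methylphenyl in place of 3,4-dimethylphenyl on an aromatic nitrogen. No measured step bears readably on this change, and every compound shown has failed to give a number. Compound 4 is therefore expected to show no measurable inhibition either, an estimated 80000 nM with a range from 30000 nM to 300000 nM. That estimate would mean an expected step that the limit leaves unreadable from compound 3 to compound 4, most likely again reported only as a limit.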

Compound 4, half-maximal inhibitory concentration: > 50000 nM
Compound 4 ended at the assay's limit (the forecaster's own chance of this, stated with the estimate: 85%); the middle value is on the limit's open side.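

Among these compounds, compound 4 stands with compound 1, compound 2 and compound 3 at a limit in this assay and not at a number, so no new step among them can be read: the limit of > 50000 nM in this assay, at which 4 of the 4 values shown sit. What these compounds leave open is how far apart they truly lie, and whether any aryl group on the aromatic nitrogen would give a measurable value in this assay at all.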